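Piperidine bis-amides: cytotoxicity in PC-3 cells, methoxy to benzoyl

The source may hold more compounds than are shown below. What is called first, only, known or untested is meant among the compounds shown, and "the series" means these compounds.

Two members of the series have been run in an ADME assay on PC-3 cells (Homo sapiens) for cytotoxicity, read by WST assay, tested at 100 uM; a lower number here means less inhibition, a higher number more inhibition at the concentration tested (going by the name of the read-out). Compound 1 `O=C(Nc1cccc(-c2cnco2)c1)C1CCCN(C(=O)c2cc(C(F)(F)F)cc(C(F)(F)F)c2)C1` gives 9% in this assay. Compound 2 `COc1cccc(C(=O)N2CCCC(C(=O)Nc3ccc(Cl)cc3)C2)c1` gives 0% in this assay, the lowest of the two numbers; its nearest neighbour is compound 1, and the gap between the two numbers lies within the scatter, so the two readings cannot be ordered. Going by the values given here, no pair in the set differs in a single place, so no measured step is available to guide the next compound.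

Compound 3 `O=C(c1ccccc1)c1cccc(C(=O)N2CCCC(C(=O)Nc3ccc(Cl)cc3)C2)c1` differs from compound 2 by one change: benzoyl in place of methoxy on an aromatic carbon. The benzoyl enters on an aromatic carbon of a six-membered aromatic ring of carbon only, meta to a large group.

With both measured numbers sitting near zero, the step of a number 8 percentage points higher from compound 2 to compound 3 (within the scatter) is expected to be small, at most a modest rise, and likely not beyond the scatter. Compound 3 is estimated at 8% in this assay, with a range from 0% to 25%.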

Compound 3, a percentage reported as inhibition, at one concentration (the size of the read-out at that concentration, not a potency): 0%
The estimate for compound 3 lay 8 percentage points above the measured number; the range from low to high includes it.
By their numbers in this assay, from the lowest: compounds 2, 3 and 1 (each within the scatter of the next).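

In this assay, going by these compounds alone, the first single-place step reads no change at the digits printed from compound 2 to compound 3 (within the scatter). On this aromatic carbon, meta to a large group, the exchange of methoxy for benzoyl brings in 8 heavy atoms and one six-membered aromatic ring in place of 2 heavy atoms and no ring, yet the step gives no readable shift in the read-out at the tested concentration. No measured property of these groups is available to set beside this step.

Going by these compounds, what an amine or a carboxylic acid on this same aromatic carbon would give remains open. Also open, on these data alone, is how benzoyl would behave on the core of compound 1, which differs from compound 2 in more than one place and so cannot be compared with it directly.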